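Compound 3 to compound 4: 1-acetylpiperidin-4-yl swap

The source may hold more compounds than are shown below. What is called first, only, known or untested is meant among the compounds shown, and "the series" means these compounds.

Compound 1 `Cn1cc(-c2cnc(NCc3c(F)ccc4c3CCO4)c3cn[nH]c(=O)c23)cn1`: 1000 nM 
Compound 2 `Cc1nccn1-c1cnc(NCc2c(F)ccc3c2CCO3)c2cn[nH]c(=O)c12`: 7000 nM 
Compound 3 `O=C1CCCN1c1cnc(NCc2c(F)ccc3c2CCO3)c2cn[nH]c(=O)c12`: < 2000 nM (a limit)
Compound 4 `CC(=O)N1CCC(c2cnc(NCc3c(F)ccc4c3CCO4)c3cn[nH]c(=O)c23)CC1`: not yet measured

All values come from a physicochemical assay for solubility, read by LC-MS, in phosphate buffer, with a stated time of 24 h, at pH 7.4 (on this read-out higher numbers stand for higher solubility and lower numbers for lower solubility), and the compounds share one core. Compound 3 stands only at a limit (< 2000 nM) and not at a number. The change to compound 4 is 1-acetylpiperidin-4-yl in place of 2-oxopyrrolidin-1-yl on an aromatic carbon on an aromatic carbon. Swaps at this place gave a 7.0-fold higher number from compound 1 to compound 2 (0.85 log units; beyond the scatter) and an at least 3.5-fold lower number from compound 2 to compound 3 (0.54 log units; beyond the scatter) and both lie beyond the scatter. Also on record is a step that the limit leaves unreadable from compound 1 to compound 3 with no size to read. Those steps involved aromatic groups, whereas here one non-aromatic ring replaces another, so no step beyond the scatter is expected in this assay in either direction. The expected change is a step that the limit leaves unreadable from compound 3 to compound 4 for this swap. The estimate for compound 4 is 1500 nM (range 400 nM to 6000 nM).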

Compound 4, solubility: < 2000 nM
Compound 4: a limit, no number (the forecaster's own chance of this, stated with the estimate: 40%); the middle value is on the limit's open side.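

In this assay compound 4 gives < 2000 nM, which is a limit and not a number. The 1-acetylpiperidin-4-yl group gives an at least 3.5-fold lower number from compound 2 to compound 4 (0.54 log units; beyond the scatter), so at this position compound 3 and compound 4, both carrying a non-aromatic ring, each read lower than compound 2. The steps from compound 3 and from compound 1 to compound 4 cannot be read, and the limit recurs: the limit of < 2000 nM in this assay, at which 2 of the 4 values shown sit.

Going by these compounds, how compound 4 ranks against compound 3 and compound 1 stays open. Also open, on these data alone, is what a free amine on the piperidine ring, or a carboxylic acid, would give here.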